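This account rests on a few compounds, and the source may have more. Where it says the series, first, only, none or still open, it means among the compounds named here.

Measured so far in an ADME assay on L02 cells (Homo sapiens) for inhibition, read by CCK-8 assay, with a stated time of 48 h; on this read-out higher numbers stand for weaker inhibition of growth and lower numbers for stronger inhibition of growth:

Compound 1 `CCN1CCN(c2ccc(Nc3ncc(Cl)c(Nc4ccccc4C)n3)nc2)CC1` gives > 100000 nM (a limit)
Compound 2 `Cc1ccccc1Nc1nc(Nc2ccc(N3CCCCC3)cn2)ncc1Cl` gives 42400 nM (a number)
Compound 3 `Cc1ccc(CNc2nc(Nc3ccc(N4CCN(C)CC4)cn3)ncc2Cl)cc1` gives > 100000 nM (a limit)

For compound 3 the reading of > 100000 nM is a limit and not a number. Among the compounds with values here, the series so far gathers at the limit of > 100000 nM in this assay, at which 2 of the 3 values shown sit, and only compound 2 gives a number.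

Compound 4 `Cc1cccc(Nc2nc(Nc3ccc(N4CCN(C)CC4)cn3)ncc2Cl)c1` keeps the rest of compound 3 and changes one group, 3-methylphenyl in place of 4-methylbenzyl on a nitrogen on an aromatic ring that is, 3-methylphenyl in place of 4-methylbenzyl on a nitrogen on an aromatic ring.

Within the data shown here, no measured step touches that nitrogen. Among the measured compounds shown here, the only measured step changes another place, piperidin-1-yl in place of 4-ethylpiperazin-1-yl on an aromatic carbon, and its size is an at least 2.3-fold lower number from compound 1 to compound 2 (0.37 log units; beyond the scatter) so it bears on compound 4 only indirectly. Compound 4 keeps the group of compound 3 at that other place, not the piperidin-1-yl of compound 2. Compound 1 has a methylphenyl group on the nitrogen and reads > 100000 nM as a limit.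

As far as these compounds go, no step beyond the scatter is therefore expected, and the direction stays open. The estimated step is an at least 1.2-fold lower number from compound 3 to compound 4 (0.09 log units; that floor lies within the scatter) and a further limit reading is quite possible. Compound 4 is estimated at 80000 nM with an expected range of 35000 nM to 200000 nM in this assay for this compound.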

Compound 4, concentration for 50% growth inhibition: 6080 nM
For compound 4 the middle estimate is 13-fold (1.12 log units) above the measured one; measured number outside the range, below it.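

In this assay, replacing 4-methylbenzyl with 3-methylphenyl on a nitrogen on an aromatic ring gives an at least 16-fold lower number from compound 3 to compound 4 (1.21 log units; beyond the scatter). Within the data shown here, this is the first measured step at this nitrogen, and it shows that the group carried there can move the read-out well beyond the scatter; the only earlier step, an at least 2.3-fold lower number from compound 1 to compound 2 (0.37 log units; beyond the scatter), concerned another place. Compound 4 therefore gives a number on a methylpiperazine-bearing compound, so a number no longer depends on the piperidin-1-yl group of compound 2, although the series still gathers at a limit: the limit of > 100000 nM in this assay, at which 2 of the 4 values shown sit.

The change alters two things at once, so the compounds shown do not separate the loss of the benzyl carbon from the move of the methyl group, which 3-methylbenzyl or 4-methylphenyl on that nitrogen would address, and the true size of the step stays open while compound 3 reads only as a limit. Also open, as far as these compounds go, is how far growth inhibition would go with piperidin-1-yl combined with the 3-methylphenyl group of compound 4, or with a carboxylic acid or an amine on that aromatic ring.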